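Swapping a phenyl for a methyl on a pyranone-bearing dihydropyridine

The source may hold more compounds than are shown below. What is called first, only, known or untested is meant among the compounds shown, and "the series" means these compounds.

Compound 1 `CCOC(=O)C1=C(C)NC(C)=C(C(=O)OCC)C1c1cc(=O)cc(-c2ccccc2)o1` and compound 2 `CCOC(=O)C1=C(C)NC(C)=C(C(=O)OCC)C1c1cc(=O)cc(C)o1` share one core. In an assay on isolated protein (strain albino) for inhibition of Voltage-dependent L-type calcium channel subunit alpha-1C (Cavia porcellus) (a higher number here means a weaker inhibitor, a lower number a stronger inhibitor), compound 1 gives 3240 nM, while compound 2 gives 35900 nM. The change between them is methyl in place of phenyl on an aromatic carbon, and it makes an 11-fold higher number from compound 1 to compound 2 (1.04 log units; beyond the scatter). Compound 3 `CCOC(=O)C1=C(C)NC(C)=C(C(=O)OC)C1c1ccc(-c2cc(=O)cc(-c3ccccc3)o2)cc1` rests on a different core; the difference between the two cores is not broken down here. In this assay compound 3 gives 94400 nM, the highest of the three values. Compound 4 `CCOC(=O)C1=C(C)NC(C)=C(C(=O)OC)C1c1ccc(-c2cc(=O)cc(C)o2)cc1` is made from compound 3 by methyl in place of phenyl on an aromatic carbon, the same change as that from compound 1 to compound 2, at the same place. Because an 11-fold higher number from compound 1 to compound 2 (1.04 log units; beyond the scatter) was large, a sizeable step is expected here too, estimated as a 4.2-fold higher number from compound 3 to compound 4 (0.63 log units; beyond the scatter), though the new core may not carry it fully. Compound 4 is therefore expected to give about 400000 nM, between 120000 nM and 1500000 nM.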

Compound 4, half-maximal inhibitory concentration: 86100 nM
Compound 4: middle estimate off by 4.6-fold (0.67 log units), on the high side; the measured number lies below the stated range.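

In this assay the swap of phenyl for methyl on the core of compound 3 gives a 1.1-fold lower number from compound 3 to compound 4 (0.04 log units; within the scatter) and so does not repeat the large step seen on the other core. The two cores respond differently to the same change at the same place: the same change on two cores in this assay, an 11-fold higher number (1.04 log units; beyond the scatter) from compound 1 to compound 2 and a 1.1-fold lower number (0.04 log units; within the scatter) from compound 3 to compound 4, 12-fold (1.08 log units) apart, beyond the scatter of two such steps. Within the data shown here, this shows that a large step on one core cannot be assumed to carry over to another, but with only one pair on each core it does not show why the two differ.

Still open, on these data alone, is whether other groups at this place, such as an amine, a carboxylic acid or a longer chain, would behave alike on both cores. Also open, as far as these compounds go, is whether any change at all would carry over between them.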